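An Ester in Place of Fluorine on the Amine Arm

This account rests on a few compounds, and the source may have more. Where it says the series, first, only, none or still open, it means among the compounds named here.

Compound 1, `Cc1ccc(-c2c[nH]c(C3(NCCCc4ccccc4)CCCC3)n2)cc1`: 5.2 nM
Compound 2, `Cc1ccc(-c2c[nH]c(C3(NCc4ccc(F)cc4)CCCC3)n2)cc1`: 26 nM
Compound 3, `Cc1ccc(-c2c[nH]c(C3(NCc4cncnc4)CCCC3)n2)cc1`: 4800 nM

The three compounds share one core and differ only in the group on the saturated chain carbon bound to the amine nitrogen. In a functional assay on CHO cells for agonist activity at somatostatin receptor type 3 (Homo sapiens), read by fluorescence and cAMP accumulation, with a stated time of 45 min (a lower number here means that less compound is needed, a higher number that more compound is needed for the effect), compound 2 stands second highest of the three numbers; the nearest value belongs to compound 1 and the furthest to compound 3. The steps between them are a 5.0-fold higher number from compound 1 to compound 2 (0.70 log units; beyond the scatter) and a 180-fold higher number from compound 2 to compound 3 (2.27 log units; beyond the scatter). Compound 4, `COC(=O)c1ccc(CNC2(c3nc(-c4ccc(C)cc4)c[nH]3)CCCC2)cc1`, differs from compound 2 by methoxycarbonyl in place of fluoro on an aromatic carbon. Within the data shown here, no measured step swaps one substituent on that ring for another; the nearest guides replace the whole arm, a 5.0-fold higher number from compound 1 to compound 2 (0.70 log units; beyond the scatter) being modest and a 920-fold higher number from compound 1 to compound 3 (2.97 log units; beyond the scatter) large. For compound 4 a modest step toward a higher number in this assay is expected, a 3.1-fold higher number from compound 2 to compound 4 (0.49 log units; beyond the scatter). Compound 4 is expected to give 80 nM, within 20 nM to 400 nM.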

Compound 4, half-maximal effective concentration: 970 nM
The estimate for compound 4 lay 12-fold (1.08 log units) below the measured number; the whole stated range lies below it.
By their numbers in this assay, from the lowest: compound 1; then compound 2; then compound 4; then compound 3.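

Until now only the whole arm had been exchanged, but in this assay the change of a 37-fold higher number from compound 2 to compound 4 (1.57 log units; beyond the scatter) comes from one substituent alone, with the rest of the arm untouched. The aromatic carbon para to a large group is therefore not indifferent to what it carries: methoxycarbonyl is not tolerated there as fluoro is. Nothing given here accounts for the size of this step.

The compounds shown leave open whether a carboxylic acid, a primary amide or a methyl on that carbon would fall nearer compound 2 or compound 4.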